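A few compounds are considered here, and "the series" means these few. Any claim that something is new, unique, unknown or untested is made for them only; others in the source may bear on it.

Compound 1 `Cc1nc(S(C)(=O)=O)ccc1Oc1ncnc(OC2CCN(C(=O)OC3COC3)CC2)c1F` gives 326 nM in a functional assay on isolated protein for inhibition of Glucose-dependent insulinotropic receptor (Homo sapiens), read by HTRF and cAMP accumulation; a higher number here means that more compound is needed for the effect, a lower number that less compound is needed. Within the data shown here, compound 2 `CCC(F)(F)C(=O)N1CCC(Oc2ncnc(Oc3ccc(S(C)(=O)=O)nc3C)c2F)CC1` gives 17.4 nM in this assay, and the single measured step, a 19-fold lower number from compound 1 to compound 2 (1.27 log units; beyond the scatter), is the only comparison available; compound 2 therefore holds the lowest of the two numbers.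

Compound 3 `Cc1nc(S(C)(=O)=O)ccc1Oc1ncnc(OC2CCN(C(=O)c3noc(C(C)(C)F)n3)CC2)c1F` differs from compound 2 by a group of 9 heavy atoms (5 carbon, 2 nitrogen, 1 oxygen, 1 fluorine; one five-membered aromatic ring with 3 hetero atoms) in place of a group of 5 heavy atoms (3 carbon, 2 fluorine; no ring), on a carbonyl carbon. Among the measured compounds shown here, the one measured step bears directly on this position: a 19-fold lower number from compound 1 to compound 2 (1.27 log units; beyond the scatter) shows that the group on the carbonyl carbon can shift the number strongly. For the measured compounds named here, that step ran from an oxygen-linked oxetane to a fluorinated alkyl chain; compound 3 keeps a fluorinated carbon on the acyl side but inside an aromatic ring, and no measured pair tells how such a ring behaves here. Compound 3 is therefore expected to stay near compound 2, with a 1.7-fold higher number from compound 2 to compound 3 (0.24 log units; within the scatter) as the expected step, and its estimate in this assay is 30 nM within a range of 8 nM to 110 nM.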

Compound 3, half-maximal effective concentration: 14 nM
Compound 3: middle estimate off by 2.1-fold (0.33 log units), on the high side, within the range that was stated.
By their numbers in this assay, from the lowest: compounds 3 and 2 (each within the scatter of the next); then compound 1.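

In this assay, the step of a 1.2-fold lower number from compound 2 to compound 3 (0.09 log units; within the scatter) shows that the 1,1-difluoropropyl on the carbonyl carbon can be replaced by a larger group holding a five-membered aromatic ring with 3 hetero atoms, with no change beyond the scatter. The ring-bearing group also matches the large shift seen earlier, with a 23-fold lower number from compound 1 to compound 3 (1.37 log units; beyond the scatter), so that shift away from the (oxetan-3-yl)oxy group does not belong to the open fluorinated chain alone. No measurement is available that explains why these two groups read alike.

The compounds shown leave open whether the fluorine of the entering group matters, since the same ring with a plain isopropyl group does not appear among them. They also leave open how an amine or a phenyl ring on the carbonyl carbon would read in this assay.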